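A few compounds are considered here, and "the series" means these few. Any claim that something is new, unique, unknown or untested is made for them only; others in the source may bear on it.

Going by the values given here, the three compounds measured so far in an ADME assay for metabolic stability, read by LC-MS, with a stated time of 3 h, at pH 6.5, tested at 50 uM (on this read-out lower numbers stand for a less stable compound and higher numbers for a more stable compound), share one core and differ in the groups attached to its two ester positions. Compound 1 `CC(C)C(=O)OCOC(=O)C1=C(S[C@@H]2CN[C@H](C(=O)Nc3cccc(C(=O)OCOC(=O)C(C)C)c3)C2)[C@H](C)[C@@H]2[C@@H]([C@@H](C)O)C(=O)N12` carries an isobutyryloxymethyl ester on both sides; in this assay compound 1 sits at a limit of the read-out, > 95%. Compound 3 `COC(=O)OCOC(=O)C1=C(S[C@@H]2CN[C@H](C(=O)Nc3cccc(C(=O)OCOC(=O)OC)c3)C2)[C@H](C)[C@@H]2[C@@H]([C@@H](C)O)C(=O)N12` carries a methoxycarbonyloxymethyl ester on both sides; in this assay compound 3 likewise sits at a limit, > 95%. Compound 2 `C[C@@H](O)[C@H]1C(=O)N2C(C(=O)OCC(F)(F)F)=C(S[C@@H]3CN[C@H](C(=O)Nc4cccc(C(=O)O)c4)C3)[C@H](C)[C@H]12` keeps a free carboxylic acid on the aryl amide side and a 2,2,2-trifluoroethyl ester on the core; for compound 2 this assay also reports only a limit, > 95%. So compound 2 stands where every value shown stands, at the limit of > 95% in this assay, at which 3 of the 3 values shown sit, and no number for it is known.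

Compound 4 `CC(C)OC(=O)C1=C(S[C@@H]2CN[C@H](C(=O)Nc3cccc(C(=O)O)c3)C2)[C@H](C)[C@@H]2[C@@H]([C@@H](C)O)C(=O)N12` differs from compound 2 in one place: isopropyl in place of 2,2,2-trifluoroethyl on an oxygen next to a carbonyl group. The free acid on the aryl amide side is kept. Among the compounds with values here, no step between two measured compounds describes this change, so there is no measured guide to its size or direction. Given that every compound shown, including compound 2 at > 95%, reaches the limit, compound 4 is expected to stay at or near it, with a step from compound 2 to compound 4 of a number no higher from compound 2 to compound 4 (the limit leaves the size open), which is none beyond the scatter. Compound 4 is therefore estimated at 95%, between 85% and 99%.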

Compound 4, percent of the compound remaining: > 95%
Compound 4: no number, only a limit (the forecaster's own chance of this, stated with the estimate: 70%); the middle value lies on the limit itself.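

In this assay compound 4 gives > 95%, which is a limit and not a number. Going by these compounds alone, compound 2 also gives only a limit, so no step between compound 2 and compound 4 can be read. What isopropyl in place of 2,2,2-trifluoroethyl changes, and how far any compound lies past the limit, stays open: the limit of > 95% in this assay, at which 4 of the 4 values shown sit.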